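The compounds below may be only part of what the source reports. "The series", "measured", "known", "first", "only" and "open" are said of these compounds alone.

Measured in an assay on isolated protein for inhibition of long-chain fatty acid transport protein 1 (Mus musculus); on this read-out higher numbers stand for weaker inhibition and lower numbers for stronger inhibition:
compound 1 `CCn1c(CNc2ccccc2)nnc1SCc1nc2cc(C)ccc2o1` gives > 10000 nM, a limit of the assay.
compound 2 `CCC(O)c1ccc2oc(CSc3nnc(CNc4ccccc4)n3CC)nc2c1` gives 3700 nM.
compound 3 `CC/C(=N/O)c1ccc2oc(CSc3nnc(CNc4ccccc4)n3CC)nc2c1` gives 200 nM.

Compound 3 holds the lowest of the two numbers in this assay; its nearest neighbour is compound 2, with a 19-fold lower number from compound 2 to compound 3 (1.27 log units; beyond the scatter). Compound 1 sits at the limit (the limit of > 10000 nM in this assay, at which 1 of the 3 values shown sits), so its distance from compound 3 is only known as a bound.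

Compound 4 `CCn1c(CNc2ccccc2)nnc1SCc1nc2cc(Cl)ccc2o1` differs from compound 3 by one chlorine atom in place of a group of 5 heavy atoms (3 carbon, 1 nitrogen, 1 oxygen; no ring), on an aromatic carbon. The group that leaves is the one whose entry on the shared core gave an at least 50-fold lower number from compound 1 to compound 3 (1.69 log units; beyond the scatter), and whose entry in place of the 1-hydroxypropyl gave a 19-fold lower number from compound 2 to compound 3 (1.27 log units; beyond the scatter); both steps were large. The only single-atom substituent seen at that carbon is the methyl of compound 1, which stays at the limit. Within the data shown here, removing the 5-atom group is therefore expected to cost most or all of what it brought, and a chlorine has no precedent that would argue otherwise.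

Compound 4 is expected to show a large rise in this assay, a 50-fold higher number from compound 3 to compound 4 (1.70 log units; beyond the scatter), most likely back to the limit of the assay. The estimate for compound 4 is 10000 nM, with a range of 3000 nM to 40000 nM.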

Compound 4, half-maximal inhibitory concentration: 2300 nM
Beside the measured number, compound 4's estimate is 4.3-fold (0.64 log units) above it, and the stated range ends above it.
By their numbers in this assay, from the lowest: compound 3; then compounds 4 and 2 (each within the scatter of the next). At a limit, above all of these: compound 1.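

Chloro in place of methyl gives an at least 4.3-fold lower number from compound 1 to compound 4 (0.63 log units; beyond the scatter), so on this aromatic carbon one chlorine atom is enough to leave the limit, although that step is known only as a bound: the limit of > 10000 nM in this assay, at which 1 of the 4 values shown sits. Chloro and 1-hydroxypropyl are not separated in this assay, with a 1.6-fold lower number from compound 2 to compound 4 (0.21 log units; within the scatter), so the longer chain shows no measurable advantage over one chlorine atom at this position. The 5-heavy-atom group of compound 3 still keeps a large margin over chloro, with a 12-fold higher number from compound 3 to compound 4 (1.06 log units; beyond the scatter), which ties the best number in the set to that particular group and not to substitution at this carbon in general.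

The compounds shown do not separate the contributions of the double bond, the hydrogen-bond donor and the hydrogen-bond acceptors of that group, so which of these features goes with the margin remains open. A propanoyl ketone or a methyl ether of the same group on this aromatic carbon would bear on that question, and a nitrile or a bromine would show how far the chloro result extends.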